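Iodo for tert-butyl: expected shift in the series

This account rests on a few compounds, and the source may have more. Where it says the series, first, only, none or still open, it means among the compounds named here.

Compound 1 `COc1cc2ncnc(Nc3ccc(NC(=O)c4ccc(C(C)(C)C)cc4)cc3)c2cc1OC` is the reference. In a functional assay on HepG2 cells (Homo sapiens) for inhibition, read by MTT assay (on this read-out higher numbers stand for weaker inhibition and lower numbers for stronger inhibition), compound 1 gives > 100000 nM, which is a limit of the assay and not a number; this is the limit of > 100000 nM in this assay, at which 1 of the 2 values shown sits. Among the compounds with values here, compound 2 `COc1cc2ncnc(Nc3ccc(NC(=O)c4ccc(Cl)cc4)cc3)c2cc1OC` gives 28000 nM in this assay, and the step of an at least 3.5-fold lower number from compound 1 to compound 2 (0.55 log units; beyond the scatter) is the one measured step that bears on the case. Compound 3 `COc1cc2ncnc(Nc3ccc(NC(=O)c4ccc(I)cc4)cc3)c2cc1OC` differs from compound 1 as iodo in place of tert-butyl on an aromatic carbon. Guided only by the chloro step, a lowering of similar size is expected for compound 3, an at least 2.8-fold lower number from compound 1 to compound 3 (0.45 log units; beyond the scatter). Compound 3 is therefore estimated at 35000 nM, expected between 12000 nM and 100000 nM.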

Compound 3, half-maximal inhibitory concentration: 40000 nM
Compound 3: middle estimate off by 1.1-fold (0.06 log units), on the low side; the range from low to high includes it.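

In this assay, iodo on the aromatic carbon para to a large group also reads lower than tert-butyl, so the drop is no longer seen with chloro alone: an at least 2.5-fold lower number from compound 1 to compound 3 (0.39 log units; beyond the scatter). Iodo and chloro are not told apart at this position: a 1.4-fold higher number from compound 2 to compound 3 (0.15 log units; within the scatter). The true size of the step from tert-butyl stays unknown, since compound 1 stands at a limit of the assay and not a number: the limit of > 100000 nM in this assay, at which 1 of the 3 values shown sits.

As far as these compounds go, whether a methyl, methoxy, amine or carboxylic acid at this position would read like the two halogens or like tert-butyl remains open. Fluoro is equally open.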